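Swapping dimethylamino for piperidin-1-yl on the shared core

A few compounds are considered here, and "the series" means these few. Any claim that something is new, unique, unknown or untested is made for them only; others in the source may bear on it.

Compounds measured so far:
- compound 1 `CN(C)C12CC(OC(=O)CN3CCCC3)C(C(c3ccccc3)C1)C(c1ccccc1)C2`: 32700 nM
- compound 2 `CN1CCN(CC(=O)NC2CC3(N(C)C)CC(c4ccccc4)C2C(c2ccccc2)C3)CC1`: 66200 nM
- compound 3 `CN(C)C12CC(OC(=O)CN3CCCCC3)C(C(c3ccccc3)C1)C(c1ccccc1)C2`: 29300 nM

All three values come from an ADME assay on L6 cells (Rattus norvegicus) for cytotoxicity, read by resazurin assay, with a stated time of 72 h; on this read-out lower numbers stand for stronger inhibition and higher numbers for weaker inhibition. Compound 1 lies within the scatter of compound 3, and the one clear gap on its scale is a 2.0-fold higher number from compound 1 to compound 2 (0.31 log units; beyond the scatter).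

The next compound is compound 4 `O=C(CN1CCCC1)OC1CC2(N3CCCCC3)CC(c3ccccc3)C1C(c1ccccc1)C2`, which departs from compound 1 in one place: piperidin-1-yl in place of dimethylamino on a saturated ring carbon. In short, this is piperidin-1-yl in place of dimethylamino on a saturated ring carbon. For the measured compounds named here, no measured step touches this group, so the data offer no direct evidence for the change. The closest parallel lies elsewhere in the molecule, where piperidin-1-yl replaces pyrrolidin-1-yl on a saturated chain carbon bound to a carbonyl carbon: a 1.1-fold lower number from compound 1 to compound 3 (0.05 log units; within the scatter). A larger exchange of the whole side group gave only a modest move, a 2.3-fold lower number from compound 2 to compound 3 (0.35 log units; beyond the scatter).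

Going by the values given here, all the measured steps are small, so only a small step is expected in this assay. The direction is uncertain, with a slight lean towards a lower number. The estimate is a 1.4-fold lower number from compound 1 to compound 4 (0.13 log units; within the scatter), which may not exceed the scatter. For compound 4 the expected value is 24000 nM, with an estimated range from 10000 nM to 55000 nM.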

Compound 4, half-maximal inhibitory concentration: 16400 nM
Compound 4: the middle estimate sits 1.5-fold (0.17 log units) above what was measured; the range from low to high includes it.
By their numbers in this assay, from the lowest: compounds 4, 3 and 1 (each within the scatter of the next); then compound 2.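

For the compounds shown here, this is the first reading at this position, since compounds 1, 2 and 3 all carry dimethylamino on that saturated ring carbon. In this assay, replacing dimethylamino (3 heavy atoms, no ring) with piperidin-1-yl (6 heavy atoms, one six-membered non-aromatic ring) gives a 2.0-fold lower number from compound 1 to compound 4 (0.30 log units; within the scatter), so the step stays inside the usual scatter and this single pair shows no clear effect, even though the entering group has more heavy atoms and brings a ring. No measurement shown here accounts for this result or links it to any property of either group.

As far as these compounds go, the exchange has been read only with the (((pyrrolidin-1-yl)methyl)carbonyl)oxy group on the core, so it remains open whether piperidin-1-yl would give a similar step alongside the side groups of compound 2 or compound 3. From the compounds shown here alone, it is also open whether a clear change would appear with a different group on this ring carbon, such as morpholin-4-yl, an unsubstituted amino group or a 4-methylpiperazin-1-yl group.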